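Thiophen-2-yl in place of benzylamino on a shared core

The source may hold more compounds than are shown below. What is called first, only, known or untested is meant among the compounds shown, and "the series" means these compounds.

Compound 1 `CN1CCC(C(=O)N2Cc3c(NC(=O)NCc4ccccc4)n[nH]c3C2(C)C)CC1` gives 2680 nM as a measured number
Compound 2 `CC(=O)N1CCC(C(=O)N2Cc3c(NC(=O)c4ccc(F)cc4)n[nH]c3C2(C)C)CC1` gives > 10000 nM as a limit

For the measured compounds named here, in a functional assay on A2780 cells (Homo sapiens) for antiproliferative activity, read by fluorescence, with a stated time of 72 h (a lower number here means a stronger inhibitor, a higher number a weaker inhibitor), compound 1 gives 2680 nM as the only true number available. Compound 2 gives > 10000 nM here, and that is a limit of the assay and not a number. Compound 1 therefore has no measured neighbour to be ranked against.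

Compound 3 `CN1CCC(C(=O)N2Cc3c(NC(=O)c4cccs4)n[nH]c3C2(C)C)CC1` is still unmeasured. It keeps the core of compound 1 and changes one group: thiophen-2-yl in place of benzylamino on a carbonyl carbon. Going by the values given here, no measured pair shows what such a swap does, so the expectation is loose. Among the compounds with values here, the only anchor is compound 1 at 2680 nM in this assay as the starting point. From there a modest gain in strength is expected, an estimated 2.7-fold lower number from compound 1 to compound 3 (0.43 log units; beyond the scatter) that lies only a little beyond the scatter. For compound 3 the estimated value is 1000 nM with an expected range from 200 nM to 6000 nM once measured.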

Compound 3, half-maximal inhibitory concentration: 30 nM
Estimate against measurement, compound 3: 33-fold (1.52 log units) above; measured number below the stated range.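

In this assay the group on this carbonyl carbon clearly matters: thiophen-2-yl in place of benzylamino gives an 89-fold lower number from compound 1 to compound 3 (1.95 log units; beyond the scatter) and so turns a weak inhibitor into a much stronger one on the same core. This single step changes several things at once, since the incoming group is smaller, has a five-membered ring holding sulfur rather than a six-membered carbon ring, and has no hydrogen-bond donor, so the step cannot show which of these differences counts. Nothing measured among these compounds explains why the number falls so far.

Going by these compounds, it remains open whether the sulfur-containing ring is needed or whether furan-2-yl or plain phenyl on the same carbonyl carbon would do as well. Also open, on these data alone, is whether a shorter amino group, such as methylamino, would restore strength.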